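The source may report more compounds than this note shows. Statements on the series, on what has been measured and on what is new or still open speak of the compounds shown alone.

Measured in a functional assay on RAW264.7 cells (Mus musculus) for inhibition, read by MTT assay; on this read-out higher numbers stand for weaker inhibition and lower numbers for stronger inhibition:
- compound 1 `Oc1ccc(/C=C/CC[C@@H](O)CCc2ccc(O)cc2)cc1`: 16100 nM
- compound 2 `Oc1ccc(/C=C/CC[C@H](O)CCc2ccc(O)c(O)c2)cc1`: 42000 nM

Of the two measured compounds, compound 2 stands highest at 42000 nM, which makes it the weaker inhibitor in this assay. Compound 1 lies lower at 16100 nM, and this gap is beyond the usual scatter.

The next compound is compound 3 `Oc1ccc(/C=C/CC[C@@H](O)CCc2ccc(O)c(O)c2)cc1`, the stereoisomer of compound 2. (the two compounds have the same atoms and bonds and differ only in configuration as drawn: 1 of 2 stereo elements differ; a stereocentre at a saturated chain carbon is drawn S in compound 2 and R in compound 3). The atoms and bonds stay the same, and a stereocentre at a saturated chain carbon is drawn S in compound 2 and R in compound 3.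

For the measured compounds named here, no measured pair isolates a change of configuration, so the data give no direct size for this step. The two measured values span only a narrow range, which argues against expecting a large shift. The expected step of a 1.4-fold lower number from compound 2 to compound 3 (0.15 log units; within the scatter) is small, slightly towards a lower number and probably within the scatter. Compound 3 is estimated at 30000 nM, with an expected range of 13000 nM to 65000 nM.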

Compound 3, half-maximal inhibitory concentration: 20600 nM
Compound 3: the middle estimate sits 1.5-fold (0.16 log units) above what was measured, within the range that was stated.
By their numbers in this assay, from the lowest: compounds 1 and 3 (each within the scatter of the next); then compound 2.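

In this assay, the series now holds a pair that isolates a stereocentre at a saturated chain carbon, and changing it from S to R as drawn gives a 2.0-fold lower number from compound 2 to compound 3 (0.31 log units; beyond the scatter), a modest step that lies beyond the scatter. This step can be assigned to configuration alone, and the reason is this: the fact that compounds 2 and 3 differ only in the configuration as drawn. For the compounds shown here, with the configuration held, hydroxy in place of hydrogen on an aromatic carbon gives a 1.3-fold higher number from compound 1 to compound 3 (0.11 log units; within the scatter), which lies within the scatter, so this pair shows no measurable effect of the added hydroxy on this read-out, and the stereocentre is the only one of the two changes with a step beyond the scatter.

On these data alone, it remains open whether the same configuration step would carry over to the core of compound 1, which has no hydroxy at that aromatic carbon. As far as these compounds go, it is also open what a methoxy group or an amine in place of the added hydroxy, or a longer chain in place of the saturated chain, would do to the number.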